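Isopropyl for methyl on the pyrazole nitrogen

A few compounds are considered here, and "the series" means these few. Any claim that something is new, unique, unknown or untested is made for them only; others in the source may bear on it.

Measured so far in a functional assay on KG-1 cells (Homo sapiens) for antiproliferative activity, read by CCK-8 assay, with a stated time of 72 h; on this read-out higher numbers stand for weaker inhibition and lower numbers for stronger inhibition:
Compound 1, `Cc1ccc(C(=O)Nc2cccc(C(F)(F)F)c2)cc1-c1ccc2c(-c3ccc(C(=O)N4CCN(C)CC4)cc3)n[nH]c2c1`, gives 300 nM.
Compound 2, `Cc1ccc(C(=O)Nc2cccc(C(F)(F)F)c2)cc1-c1ccc2c(-c3cnn(C)c3)n[nH]c2c1`, gives 65.7 nM.

Of these two, compound 2 gives the lower number, and the gap to compound 1 lies beyond the usual scatter. Compound 3, `Cc1ccc(C(=O)Nc2cccc(C(F)(F)F)c2)cc1-c1ccc2c(-c3cnn(C(C)C)c3)n[nH]c2c1`, has not yet been measured. It differs from compound 2 in one place: isopropyl in place of methyl on an aromatic nitrogen. Among the measured compounds shown here, no measured pair shows what this change does, so the step of a 1.2-fold higher number from compound 2 to compound 3 (0.09 log units; within the scatter) is expected to stay within the scatter, in no clear direction. Compound 3 is therefore expected to give about 80 nM, with a range from 30 nM to 250 nM.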

Compound 3, half-maximal inhibitory concentration: 452 nM
Compound 3: middle estimate off by 5.7-fold (0.75 log units), on the low side; measured number outside the range, above it.
By their numbers in this assay, from the lowest: compound 2; then compounds 1 and 3 (each within the scatter of the next).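

On this nitrogen of the pyrazole, the choice of alkyl group matters: in this assay, replacing methyl with isopropyl gives a 6.9-fold higher number from compound 2 to compound 3 (0.84 log units; beyond the scatter). This change adds only carbon, with no change in ring count, hydrogen-bond donors, hydrogen-bond acceptors or net charge, so even a purely carbon change here can shift the result beyond the scatter. Nothing measured here accounts for the rise.

The compounds shown leave open how ethyl or cyclopropyl would read at this nitrogen. Going by these compounds, a plain hydrogen there, or a longer chain ending in an amine or an alcohol, also remains open.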